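A few compounds are considered here, and "the series" means these few. Any claim that something is new, unique, unknown or untested is made for them only; others in the source may bear on it.

- Compound 1 `CC(=O)c1ccc(NC(=O)Cn2nc(-c3ccc(Cl)cc3)nc2N)cc1`: 28%
- Compound 2 `C/C(=N/O)c1ccc(NC(=O)Cn2nc(C(F)(F)F)nc2N)cc1`: 31%
- Compound 3 `C/C(=N/O)c1ccc(NC(=O)Cn2nc(-c3ccccc3)nc2N)cc1`: 30%

In a functional assay on NCI-H522 cells (Homo sapiens) for inhibition, read by sulforhodamine B assay, with a stated time of 48 h, tested at 10 uM (on this read-out higher numbers stand for more inhibition of growth at the one concentration tested and lower numbers for less inhibition of growth), compound 2 gives 31%, which lies within the scatter of the other two compounds. Compound 4 `CC(=O)c1ccc(NC(=O)Cn2nc(C(F)(F)F)nc2N)cc1` is not yet measured and differs from compound 2 in one place: a group of 3 heavy atoms (2 carbon, 1 oxygen; no ring) in place of a group of 4 heavy atoms (2 carbon, 1 nitrogen, 1 oxygen; no ring), on an aromatic carbon. Going by the values given here, no measured step makes this exact change. The only one, a number 1 percentage points lower from compound 2 to compound 3 (within the scatter), concerns a different place in the molecule. Compound 1 already carries the acetyl group, and its 28% also sits within the scatter of the others. No step beyond the scatter is therefore expected, and the estimated change is a number 2 percentage points lower from compound 2 to compound 4 (within the scatter). Compound 4 is expected at 29%, with an estimated range of 18% to 40%.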

Compound 4, percent growth inhibition at one concentration: 21%
For compound 4 the middle estimate is 8 percentage points above the measured one; measured number inside the range.
By their numbers in this assay, from the lowest: compounds 4, 1, 3 and 2 (each within the scatter of the next).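

At the ring position para to a large group, acetyl in place of the group of 4 heavy atoms, which also takes away the hydrogen-bond donor counted in that group, gives a number 10 percentage points lower from compound 2 to compound 4 (within the scatter) in this assay. This exchange is therefore not shown to matter at the one concentration tested. The same holds for trifluoromethyl in place of 4-chlorophenyl, with a number 7 percentage points lower from compound 1 to compound 4 (within the scatter).

As far as these compounds go, whether an amine or a carboxylic acid at this ring position would give a step beyond the scatter stays open. Nothing available explains these small differences.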